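The source may report more compounds than this note shows. Statements on the series, on what has been measured and on what is new or still open speak of the compounds shown alone.

In a functional assay on MT4 cells (Homo sapiens) for cytotoxicity (a higher number here means that more compound is tolerated, a lower number that less compound is tolerated), compound 1 `CCC(C)Sc1nc(O)cc(C(CC)c2ccccc2)n1` reads > 200000 nM, which is a limit of the assay. Going by the values given here, compound 2 `CCC(c1ccccc1)c1cc(O)nc(SC2CCCC2)n1` gives 50000 nM, the only actual number so far. Next is compound 3 `CCC(c1ccccc1)c1cc(O)nc(SC2CCCCC2)n1`, with cyclohexyl in place of cyclopentyl on a sulfur. Among the compounds with values here, one measured step bears on this change, an at least 4.0-fold lower number from compound 1 to compound 2 (0.60 log units; beyond the scatter), which is beyond the scatter and also alters the group on the sulfur. On these data alone, that step starts from the limit of > 200000 nM in this assay, at which 1 of the 2 values shown sits, so its full size is unknown. Within the data shown here, it is the only guide, and the swap from cyclopentyl to cyclohexyl looks like a smaller edit than the one in that step. In this assay, the expected step is a 1.4-fold lower number from compound 2 to compound 3 (0.15 log units; within the scatter), a small move toward less compound tolerated that may not clear the scatter. For compound 3, the estimated value is 35000 nM, with an expected range of 12000 nM to 100000 nM.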

Compound 3, half-maximal cytotoxic concentration: 51000 nM
Compound 3: the middle estimate sits 1.5-fold (0.16 log units) below what was measured; the measured number falls inside the stated range.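

In this assay, the new step is a 1.0-fold higher number from compound 2 to compound 3 (0.01 log units; within the scatter), so cyclopentyl and cyclohexyl on the sulfur cannot be told apart, and adding a carbon to the ring changes nothing readable here. Against sec-butyl, cyclohexyl gives an at least 3.9-fold lower number from compound 1 to compound 3 (0.59 log units; beyond the scatter), the same direction as the step already seen with cyclopentyl, so two rings now stand on the lower side of the open chain. Compound 1 reads as a limit of the assay, so the full size of that step stays unknown: the limit of > 200000 nM in this assay, at which 1 of the 3 values shown sits.

Open, on these data alone, is whether a longer chain such as n-hexyl on the sulfur, or a cyclohexyl ring carrying an amine, would read with the two rings or with sec-butyl. Also open, as far as these compounds go, is whether the step from sec-butyl holds on any core other than the one shared by these three compounds.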